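Sulfone series on the shared core: step to compound 4

The source may hold more compounds than are shown below. What is called first, only, known or untested is meant among the compounds shown, and "the series" means these compounds.

Compound 1 `CC(O)(CSc1ccc(Cl)cc1)c1nc(-c2ccc(Cl)cc2)no1` is the thioether of the set; in a functional assay on DU-145 cells (Homo sapiens) for cytotoxicity, read by MTT assay (a higher number here means a weaker inhibitor, a lower number a stronger inhibitor), compound 1 gives 14500 nM. Compound 2 `CC(O)(CS(=O)(=O)c1ccc(F)cc1)c1nc(-c2ccc(Cl)cc2)no1` carries the sulfone with a fluoro on its aryl ring. In this assay compound 2 reaches only a limit, > 100000 nM. Compound 3 `CC(O)(CS(=O)(=O)c1ccc(Cl)cc1)c1nc(-c2ccc(Cl)cc2)no1` is the chloro counterpart on that aryl ring; in this assay compound 3 likewise gives only a limit, > 100000 nM. The step that the two limits leave unreadable from compound 2 to compound 3 is therefore unreadable, since both values sit at the limit of > 100000 nM in this assay, at which 2 of the 3 values shown sit. Compound 3 thus stands at the limit of this assay, not at a number, and one further value in the set is a limit as well.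

Compound 4 `CC(O)(CS(=O)(=O)c1ccc(Cl)cc1)c1nc(-c2ccccc2)no1` differs from compound 3 by hydrogen in place of chloro on an aromatic carbon, which cut one bond further out reads 4-chlorophenyl to phenyl. Going by the values given here, no measured step touches this ring; the single measured step concerns the other aryl ring and its size is not readable. The expectation for compound 4 is that it stays near the limit, the step of a number no higher from compound 3 to compound 4 (the limit leaves the size open) being expected to be small or none beyond the scatter. Compound 4 is estimated at 100000 nM, with a range from 30000 nM to 300000 nM.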

Compound 4, half-maximal inhibitory concentration: > 100000 nM
Compound 4: a limit, no number (the forecaster's own chance of this, stated with the estimate: 70%); the middle value lies on the limit itself.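

Compound 3 and compound 4 both stand only at a limit, not at a number, so no step between them can be read in this assay: the limit of > 100000 nM in this assay, at which 3 of the 4 values shown sit.

The compounds shown leave open whether 4-chlorophenyl to phenyl has any effect on the sulfones, since only the thioether, compound 1, gives a number.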